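The source may hold more compounds than are shown below. What is called first, only, known or untested is meant among the compounds shown, and "the series" means these compounds.

Series notes. Compound 3 `CCOC(=O)C1=C(C)N/C(=C/c2cc(C)n(-c3ccc(SC)cc3)c2C)C1=O` gives the lowest of the three numbers in an ADME assay on L6 cells (Rattus norvegicus) for cytotoxicity, read by resazurin assay, with a stated time of 72 h (on this read-out lower numbers stand for an effect already at smaller amounts and higher numbers for an effect only at larger amounts of compound), at 54000 nM. Compound 1 `CCOC(=O)C1=C(C)N/C(=C/c2cc(C)n(-c3ccc(OC)cc3)c2C)C1=O` gives 140000 nM in this assay, and compound 2 `CCOC(=O)C1=C(C)N/C(=C/c2cc(C)n(-c3ccc([S+](C)[O-])cc3)c2C)C1=O` gives 220000 nM. The steps at the same aromatic carbon were modest: a 2.6-fold lower number from compound 1 to compound 3 (0.41 log units; beyond the scatter) and a 4.1-fold lower number from compound 2 to compound 3 (0.61 log units; beyond the scatter), while the step of a 1.6-fold higher number from compound 1 to compound 2 (0.20 log units; within the scatter) stayed within the scatter. Compound 4 `CCOC(=O)C1=C(C)N/C(=C/c2cc(C)n(-c3ccc(CN4CCCCC4)cc3)c2C)C1=O` differs from compound 3 by (piperidin-1-yl)methyl in place of methylsulfanyl on an aromatic carbon. Going by the values given here, no measured step exchanges a group of this kind or size, so the three steps set only a scale: substituent changes at this carbon moved the number by modest amounts. For compound 4 a step of a 1.3-fold higher number from compound 3 to compound 4 (0.11 log units; within the scatter) is expected, leaving it close to the measured compounds. Compound 4 is estimated at 70000 nM, within 25000 nM to 200000 nM.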

Compound 4, half-maximal effective concentration in the L6 assay: 81000 nM
Compound 4: middle estimate off by 1.2-fold (0.06 log units), on the low side; measured number inside the range.
By their numbers in the L6 assay, from the lowest: compounds 3, 4, 1 and 2 (each within the scatter of the next, the first and the last beyond it).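

In the L6 assay, a much larger group bearing a ring fits at this aromatic carbon with little separation from the smaller groups: a 1.5-fold higher number from compound 3 to compound 4 (0.18 log units; within the scatter) and a 1.7-fold lower number from compound 1 to compound 4 (0.24 log units; within the scatter), while only a 2.7-fold lower number from compound 2 to compound 4 (0.43 log units; beyond the scatter) lies beyond the scatter. The same exchange gives a large separation in a physicochemical assay for solubility, read by nephelometry, measured as kinetic solubility, at pH 2.0; on this read-out higher numbers stand for higher solubility and lower numbers for lower solubility: the measured solubility of compound 3, 3.1 ug/mL, and of compound 4, 50 ug/mL, a 16-fold higher number (1.21 log units; beyond the scatter)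
In the physicochemical assay compound 3 gives 3.1 ug/mL and compound 4 gives 50 ug/mL on this read-out.

Open, from the compounds shown here alone, is whether a (morpholin-4-yl)methyl group, an open-chain amine or a carboxylic acid at this carbon would give the same pattern. The compounds shown also leave open whether the ring or the nitrogen of (piperidin-1-yl)methyl carries it.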